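Ring-amine substituent variation in the growth hormone secretagogue series

The source may hold more compounds than are shown below. What is called first, only, known or untested is meant among the compounds shown, and "the series" means these compounds.

Three measured members share one core and differ only in the group on the amine nitrogen of the six-membered ring. Compound 1 `COc1cccc(-n2cc3nc(-c4cccnc4C)n(C[C@H]4CCCN(CC5CCCCC5)C4)c(=O)c3n2)c1` bears cyclohexyl there; in an assay on HEK293 cells for displacement of a labelled ligand from growth hormone secretagogue receptor type 1 (Homo sapiens), with a stated time of 60 min (a lower number here means a stronger inhibitor, a higher number a weaker inhibitor), compound 1 gives 200 nM. Compound 2 `COc1cccc(-n2cc3nc(-c4cccnc4C)n(C[C@H]4CCCN(CC5CCC5)C4)c(=O)c3n2)c1` bears cyclobutyl, and in this assay compound 2 gives 1.6 nM. Compound 3 `COc1cccc(-n2cc3nc(-c4cccnc4C)n(C[C@H]4CCCN(CC(C)C)C4)c(=O)c3n2)c1` bears isobutyl, and in this assay compound 3 gives 5.7 nM. Compound 3 thus stands second highest of the three numbers: a 35-fold lower number from compound 1 to compound 3 (1.55 log units; beyond the scatter), while a 3.6-fold higher number from compound 2 to compound 3 (0.55 log units; beyond the scatter).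

Compound 4 `COC[C@H](C)N1CCC[C@H](Cn2c(-c3cccnc3C)nc3cn(-c4cccc(OC)c4)nc3c2=O)C1` is the next step from compound 3: 1-(methoxymethyl)ethyl in place of isobutyl on an amine nitrogen in a ring. The measured steps bear on it only loosely. a 130-fold lower number from compound 1 to compound 2 (2.10 log units; beyond the scatter) and a 35-fold lower number from compound 1 to compound 3 (1.55 log units; beyond the scatter) are large steps from the six-membered ring to smaller groups, whereas a 3.6-fold higher number from compound 2 to compound 3 (0.55 log units; beyond the scatter) is a modest step between two small groups. Among the compounds with values here, no measured step introduces an ether oxygen or a branch at the carbon bound to the ring nitrogen, so the direction cannot be read from the series. For compound 4 the expected step is a 1.6-fold higher number from compound 3 to compound 4 (0.20 log units; within the scatter), a modest change in this assay of uncertain direction. Compound 4 is therefore estimated at 9 nM, within 2.5 nM to 40 nM.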

Compound 4, half-maximal inhibitory concentration: 1.7 nM
Beside the measured number, compound 4's estimate is 5.3-fold (0.72 log units) above it; the whole stated range lies above it.
By their numbers in this assay, from the lowest: compounds 2 and 4 (each within the scatter of the next); then compound 3; then compound 1.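

In this assay, within the data shown here, the amine nitrogen in the ring takes 1-(methoxymethyl)ethyl in place of isobutyl with a 3.4-fold lower number from compound 3 to compound 4 (0.53 log units; beyond the scatter), the first step that brings in an ether oxygen, a branch at the carbon bound to the ring nitrogen and a defined stereocentre on this substituent. The same group in place of cyclobutylmethyl gives a 1.1-fold higher number from compound 2 to compound 4 (0.03 log units; within the scatter), so at this position an open-chain substituent carrying an ether oxygen and a cycloalkyl-bearing one cannot be told apart in this assay. In place of cyclohexylmethyl it gives a 120-fold lower number from compound 1 to compound 4 (2.07 log units; beyond the scatter), which leaves compound 1 with the highest number of the four, its steps to each of the others lying beyond the scatter.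

No measurement at hand accounts for the step from isobutyl, and that step changes the oxygen and the branch together. Going by these compounds, the contributions of the two remain open: sec-butyl would carry the branch alone, 2-methoxyethyl the ether alone, and the opposite configuration at the new stereocentre would test its role.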